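Adding an amino group to compound 3

A few compounds are considered here, and "the series" means these few. Any claim that something is new, unique, unknown or untested is made for them only; others in the source may bear on it.

Values measured in a functional assay on HT-1080 cells (Homo sapiens) for antiproliferative activity, read by MTT assay, with a stated time of 72 h; on this read-out lower numbers stand for stronger inhibition and higher numbers for weaker inhibition:
- Compound 1 `COc1ccc(-c2ssc(=S)c2-c2cc(OC)c(OC)c(OC)c2)cc1`: 18600 nM
- Compound 2 `COc1ccc(-c2ssc(=S)c2-c2cc(OC)c(OC)c(OC)c2)cc1O`: 231 nM
- Compound 3 `COc1ccc(-c2c(-c3cc(OC)c(OC)c(OC)c3)ssc2=S)cc1`: 2270 nM

Compound 3 holds the middle place of the three, with a lower number than compound 1 and a higher one than compound 2. Compound 4 `COc1ccc(-c2c(-c3cc(OC)c(OC)c(OC)c3)ssc2=S)cc1N` differs from it in one place: amino in place of hydrogen on an aromatic carbon. This is amino in place of hydrogen on an aromatic carbon, turning 4-methoxyphenyl into 3-amino-4-methoxyphenyl.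

The closest measured precedent is the addition of hydroxy, also ortho to a methoxy group: an 81-fold lower number from compound 1 to compound 2 (1.91 log units; beyond the scatter). That large step involved a different group and a different parent compound, so a drop in this assay is expected, but a smaller one. For compound 4 the estimated value is 250 nM, within an expected range of 35 nM to 1800 nM. The expected change is a 9.1-fold lower number from compound 3 to compound 4 (0.96 log units; beyond the scatter).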

Compound 4, half-maximal inhibitory concentration: 3000 nM
Beside the measured number, compound 4's estimate is 12-fold (1.08 log units) below it, outside the stated range (above it).
By their numbers in this assay, from the lowest: compound 2; then compounds 3 and 4 (each within the scatter of the next); then compound 1.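

In this assay, amino in place of hydrogen on this aromatic carbon, ortho to a methoxy group, gives a 1.3-fold higher number from compound 3 to compound 4 (0.12 log units; within the scatter), so this change makes no measurable difference on compound 3. No measured evidence bears on this result.

The large step of an 81-fold lower number from compound 1 to compound 2 (1.91 log units; beyond the scatter) involved hydroxy on a different parent, so these compounds cannot tell whether the group or the parent separates the two outcomes. Going by these compounds, how a methyl group or a carboxylic acid at this same place on compound 3 would read also remains open.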